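The source may report more compounds than this note shows. Statements on the series, on what has been measured and on what is new or still open speak of the compounds shown alone.

Compound 1 `C[C@@H](CNc1ccc(OC(F)(F)F)cc1)NC(=O)[C@H](CC1CCCCC1)NC(=O)O[C@@H]1CCOC1` and compound 2 `C[C@@H](CNc1ccc(OC(F)(F)F)cc1)NC(=O)[C@H](CC1CCCCC1)NC(=O)N1CCOCC1` share one core and differ only at a carbonyl carbon. In an assay on isolated protein for inhibition of cathepsin S (Homo sapiens) (a higher number here means a weaker inhibitor, a lower number a stronger inhibitor), compound 1 gives 42 nM, and compound 2 gives 11 nM. The step of a 3.8-fold lower number from compound 1 to compound 2 (0.58 log units; beyond the scatter) is the only measured one. Compound 2 therefore stands lowest of the two numbers, with compound 1 as its nearest neighbour.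

Compound 3 `CS(=O)(=O)CC[C@@H](CNc1ccc(OC(F)(F)F)cc1)NC(=O)[C@H](CC1CCCCC1)NC(=O)N1CCOCC1` departs from compound 2 at a different place: the change is (methylsulfonyl)methyl in place of hydrogen on a saturated chain carbon, two bonds along the chain from an amide-type nitrogen. Within the data shown here, the single measured step, which concerns the carbonyl carbon, does not bear on this change; nothing among the measured compounds tests what happens on the saturated chain carbon two bonds from the amide-type nitrogen. Among the measured compounds shown here, with no step touching that place, the expectation is a step of no clear direction, probably within the scatter, and the estimated step is a 1.1-fold higher number from compound 2 to compound 3 (0.04 log units; within the scatter). Compound 3 is accordingly expected to give about 12 nM in this assay, with a range from 3 nM to 50 nM to reflect the missing precedent.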

Compound 3, inhibition constant: 5 nM
The estimate for compound 3 lay 2.4-fold (0.38 log units) above the measured number, within the range that was stated.
By their numbers in this assay, from the lowest: compound 3; then compound 2; then compound 1.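

The saturated chain carbon two bonds along the chain from an amide-type nitrogen tolerates a substantial addition. In this assay, (methylsulfonyl)methyl in place of hydrogen, a group of 5 heavy atoms, gives a 2.2-fold lower number from compound 2 to compound 3 (0.34 log units; beyond the scatter), a modest step but one that takes the number down rather than up. Among these compounds, this is the first reading at this place, since the earlier step concerned only the carbonyl carbon, and nothing available accounts for the direction or size of the new step.

The compounds shown leave open whether the sulfur and its two oxygens matter or whether the longer chain alone is enough, a question that a plain propyl group or a 2-(methylsulfanyl)ethyl group in place of the 2-(methylsulfonyl)ethyl group would address. Also open, from the compounds shown here alone, is whether the step would hold with (oxolan-3-yl)oxy rather than morpholin-4-yl on the carbonyl carbon, and whether a chain ending in an amine or a carboxylic acid would be accepted at this place.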